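Swapping ethyl(methyl)amino for nitro in compound 3

The compounds below may be only part of what the source reports. "The series", "measured", "known", "first", "only" and "open" are said of these compounds alone.

Of the compounds shown here, three have been measured in a functional assay on the whole organism with Rattus norvegicus as the target (on this read-out lower numbers stand for an effect already at smaller amounts and higher numbers for an effect only at larger amounts of compound), so far. Compound 1 (`CCOC(=O)C(=O)Nc1ccc(N)cc1C#N`) gives 1 mg/kg and compound 2 (`CCOC(=O)C(=O)Nc1cc(N(C)C)ccc1C#N`) gives 1.9 mg/kg in this test. Compound 3 (`CCOC(=O)C(=O)Nc1cccc(N(C)CC)c1C#N`) gives 0.3 mg/kg and so holds the lowest of the three numbers. Its distance from each of the other two lies beyond the usual scatter, with compound 1 the nearer and compound 2 the further.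

Compound 4 (`CCOC(=O)C(=O)Nc1cccc([N+](=O)[O-])c1C#N`) is the next to be read. It carries nitro in place of ethyl(methyl)amino on an aromatic carbon, ortho to a cyano group (nitro in place of ethyl(methyl)amino on an aromatic carbon). Among the measured compounds shown here, none of the measured compounds carries a nitro group, and no measured pair isolates a single change, so the data offer no direct precedent for this step.

Compound 3 sits at the low end of the series with 0.3 mg/kg as its number, which leaves a move upward as the likelier outcome, toward the region of the other two compounds. In this assay the expected change is a 5.0-fold higher number from compound 3 to compound 4 (0.70 log units; beyond the scatter) and this estimated rise would lie beyond the scatter, although with wide uncertainty. For compound 4 the estimate is 1.5 mg/kg with an expected range from 0.3 mg/kg to 8 mg/kg once the measurement is made.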

Compound 4, dose for half-maximal effect: 0.4 mg/kg
Compound 4: the middle estimate sits 3.8-fold (0.57 log units) above what was measured; the measured number falls inside the stated range.
By their numbers in this assay, from the lowest: compounds 3 and 4 (each within the scatter of the next); then compounds 1 and 2 (each within the scatter of the next).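

In this assay, among the compounds shown here, the step of a 1.3-fold higher number from compound 3 to compound 4 (0.12 log units; within the scatter) is the first comparison that isolates a change in one place, since the earlier compounds offered no such pair. It shows that nitro in place of ethyl(methyl)amino on an aromatic carbon, ortho to a cyano group and meta to a group of 8 heavy atoms, leaves the read-out within the scatter, so at this position the two groups cannot be told apart in this test even though they differ in their atoms and in their hydrogen-bond acceptor count. Nothing available explains why the two groups give such matching numbers.

On these data alone, it remains open whether this match extends to other groups at the same position, such as a primary amine, a methoxy group or a plain hydrogen, and whether a longer chain on the nitrogen would fit the same picture. One pair also cannot say whether the match would survive a change elsewhere on the shared core, for instance a carboxylic acid in place of the ethyl ester.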